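This account rests on a few compounds, and the source may have more. Where it says the series, first, only, none or still open, it means among the compounds named here.

Working notes on the series. Compound 1 `Cc1ccc(-n2nc(C(C)(C)C)cc2NC(=O)Nc2cc(C(F)(F)F)cc(C(F)(F)F)c2)cc1` and compound 2 `CC(C)(C)c1cc(NC(=O)Nc2cc(C(F)(F)F)cc(C(F)(F)F)c2)n(-c2ccc(F)cc2)n1` share one core and differ at a single aromatic carbon. Among the compounds with values here, in an assay on isolated protein for inhibition of Ephrin type-A receptor 2 (Homo sapiens), read by thermal shift assay, tested at 10 uM (on this read-out higher numbers stand for stronger stabilisation of the target against heat and lower numbers for weaker stabilisation of the target), compound 1 gives 0.8 degrees C, and compound 2 gives 0.4 degrees C. The one measured step, a number 0.40 degrees C lower from compound 1 to compound 2 (within the scatter), is the only comparison in hand. Of the two numbers compound 2 holds the smaller, though its gap to compound 1 falls within the scatter, so no ranking is drawn.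

Compound 3 `CC(C)(C)c1cc(NC(=O)Nc2cc(C(F)(F)F)cc(C(F)(F)F)c2)n(C(C)(C)C)n1` differs from compound 2 by tert-butyl in place of 4-fluorophenyl on an aromatic nitrogen. Within the data shown here, no measured step touches the aromatic nitrogen; the only step known, a number 0.40 degrees C lower from compound 1 to compound 2 (within the scatter), concerns a group on an aromatic carbon and was small. The series therefore gives no ground for a step beyond the scatter in this assay, in either direction. For compound 3 the expected step is a number 0.10 degrees C lower from compound 2 to compound 3 (within the scatter). In this assay compound 3 is estimated at 0.3 degrees C, with a range from -0.7 degrees C to 1.3 degrees C.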

Compound 3, shift of the target's melting temperature: 0.5 degrees C
Beside the measured number, compound 3's estimate is 0.20 degrees C below it, within the range that was stated.
By their numbers in this assay, from the lowest: compounds 2, 3 and 1 (each within the scatter of the next).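

In this assay, the aromatic nitrogen is now probed directly: exchanging 4-fluorophenyl for tert-butyl gives a number 0.10 degrees C higher from compound 2 to compound 3 (within the scatter), and exchanging 4-methylphenyl for tert-butyl gives a number 0.30 degrees C lower from compound 1 to compound 3 (within the scatter). Thus, across these three compounds, the six-membered aromatic ring on this nitrogen can be replaced by a group with no ring without a step beyond the scatter, whereas the earlier pair tested only a change on the aromatic carbon of that ring. No supporting measurement bears on this result.

From the compounds shown here alone, it remains open whether a different kind of group on this nitrogen, such as a carboxylic acid or a longer chain ending in an amine, would produce a step beyond the scatter. Going by these compounds, the effect of replacing the tert-butyl on the ring carbon or either trifluoromethyl group also remains open.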